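Swapping methyl for bromo on a soluble series

The compounds below may be only part of what the source reports. "The series", "measured", "known", "first", "only" and "open" are said of these compounds alone.

Measured so far in a physicochemical assay for solubility, read by nephelometry, in phosphate buffer, measured as kinetic solubility, at pH 7.4; a lower number here means a less soluble compound, a higher number a more soluble compound:
compound 1 `CCOC(=O)c1oc2ccccc2c1C`: 200000 nM
compound 2 `Cc1c(-c2c3c(N)n[nH]c(=O)c3nn2-c2ccc(NC(=O)/C=C/CN(C)C)cc2)oc2ccc(Cl)cc12`: 200000 nM
compound 3 `Cc1ccc2oc(-c3c4c(N)n[nH]c(=O)c4nn3-c3ccc(NC(=O)/C=C/CN(C)C)cc3)c(C)c2c1`: 50000 nM

Of these three, compound 3 gives the lowest number, at 50000 nM. Compound 1 and compound 2 both read higher, and their two numbers are the same.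

The next compound is compound 4 `Cc1c(-c2c3c(N)n[nH]c(=O)c3nn2-c2ccc(NC(=O)/C=C/CN(C)C)cc2)oc2ccc(Br)cc12`, which has not yet been measured. It differs from compound 3 by one substitution, bromo in place of methyl on an aromatic carbon.

Among the measured compounds shown here, only one measured step bears on this change. Going a 4.0-fold lower number from compound 2 to compound 3 (0.60 log units; beyond the scatter), a modest step beyond the scatter, methyl took the place of chloro on an aromatic carbon. For the measured compounds named here, compound 4 reverses that substitution in form, but with bromo rather than chloro, and no measured step involves bromo. Compound 1 is linked to compound 3 by no single change, so it adds nothing here. Going by the values given here, with one step as the only guide, a rise of similar or slightly smaller size is expected in this assay. The estimated step is a 3.0-fold higher number from compound 3 to compound 4 (0.48 log units; beyond the scatter).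

Compound 4 is expected at about 150000 nM, with an estimated range of 60000 nM to 300000 nM.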

Compound 4, solubility: 50000 nM
Beside the measured number, compound 4's estimate is 3.0-fold (0.48 log units) above it, and the stated range ends above it.
By their numbers in this assay, from the lowest: compounds 3 and 4 (each within the scatter of the next); then compounds 1 and 2 (each within the scatter of the next).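

In this assay, the exchange of methyl for bromo on this aromatic carbon gives no change at the digits printed from compound 3 to compound 4 (within the scatter) and so does not separate the two groups at this position. Bromo in place of chloro gives a 4.0-fold lower number from compound 2 to compound 4 (0.60 log units; beyond the scatter) and is a step of the same printed size as the earlier change of chloro to methyl, a 4.0-fold lower number from compound 2 to compound 3 (0.60 log units; beyond the scatter), so among these three compounds that differ at this one position, compound 2 with its chloro is the one that stands apart, while compound 3 and compound 4 read alike. No outside evidence bears on this result.

The compounds shown leave open where fluoro, methoxy or an amine on the same aromatic carbon would fall, whether with the chloro compound, with the methyl and bromo pair, or elsewhere. They also leave open whether the gap between chloro and the other two groups would persist with a different group in place of the dimethylamino end of the side chain, as each comparison here rests on a single pair of compounds.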